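The source may report more compounds than this note shows. Statements on the series, on what has been measured and on what is new or still open speak of the compounds shown alone.

Values measured in an ADME assay on SH-SY5Y cells (Homo sapiens) for cytotoxicity, read by sulforhodamine B assay, with a stated time of 72 h (on this read-out higher numbers stand for weaker inhibition and lower numbers for stronger inhibition), so far:
- Compound 1 `O=C(NCCNc1cccc2ccccc12)C1CCN(Cc2ccccc2)CC1` gives 13600 nM
- Compound 2 `O=C(Nc1nccs1)C1CCN(Cc2ccccc2)CC1` gives 76600 nM
- Compound 3 `Cc1c(NC(=O)C2CCN(Cc3ccccc3)CC2)c(=O)n(-c2ccccc2)n1C` gives > 100000 nM

Only two of these entries are true numbers. Of that pair, compound 2 has the higher number and so the weaker inhibition, and its gap to compound 1 lies beyond the usual scatter. The entry for compound 3 is a limit of the assay and not a number.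

Compound 4 `O=C(NCc1cccnc1)C1CCN(Cc2ccccc2)CC1` has not yet been measured. Going from compound 2 to compound 4, (pyridin-3-yl)methyl takes the place of 1,3-thiazol-2-yl on an amide-type nitrogen ((pyridin-3-yl)methyl in place of 1,3-thiazol-2-yl on an amide-type nitrogen). Within the data shown here, no two measured compounds differ in one place only, so no measured step can guide this change. With compound 2 at 76600 nM as the closest reference, no step beyond the scatter is expected in this assay for this change. The estimated step of a 1.0-fold higher number from compound 2 to compound 4 (0.02 log units; within the scatter) is therefore expected to stay within the usual scatter. Compound 4 is estimated at 80000 nM with an expected range from 30000 nM to 180000 nM as its two ends.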

Compound 4, half-maximal inhibitory concentration: > 100000 nM
Compound 4: no number, only a limit (the forecaster's own chance of this, stated with the estimate: 40%); middle value at least 1.2-fold (0.09 log units) away from the limit.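

In this assay compound 4 gives > 100000 nM, which is a limit of the assay and not a number. Among these compounds, this is the first pair that differs in one place only, on an amide-type nitrogen, and placing (pyridin-3-yl)methyl where 1,3-thiazol-2-yl stood gives an at least 1.3-fold higher number from compound 2 to compound 4 (0.11 log units; that floor lies within the scatter). The change brings no lower number, yet the step can be read only as a floor, and its true size stays hidden because the read-out stops at a ceiling: the limit of > 100000 nM in this assay, at which 2 of the 4 values shown sit.

The compounds shown leave open how a plain phenyl or a small methyl group on this nitrogen would read. On these data alone, it also remains open whether a carboxylic acid added to the pyridine ring would give a value that can be read as a true number.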